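A few compounds are considered here, and "the series" means these few. Any claim that something is new, unique, unknown or untested is made for them only; others in the source may bear on it.

Measured compounds:
- compound 1, `COc1ccc(/C=C/C(=O)c2cc(-c3ccc(OC)c(OC)c3)n3nc(-c4ccccc4)cc3n2)cc1`: 22000 nM in a functional assay on MDA-MB-231 cells (Homo sapiens) for antiproliferative activity, read by MTT assay, with a stated time of 24 h; a higher number here means a weaker inhibitor, a lower number a stronger inhibitor
- compound 2, `COc1ccc(-c2cc(C(=O)/C=C/c3ccc(Cl)cc3)nc3cc(-c4ccccc4)nn23)cc1OC`: 23700 nM in this assay

Within the data shown here, compound 2 has the highest number of the two in this assay, but its only neighbour, compound 1, lies within the scatter: a 1.1-fold higher number from compound 1 to compound 2 (0.03 log units; within the scatter). So the two compounds cannot be told apart on these numbers.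

Compound 3, `COc1ccc(C(=O)/C=C/c2cc(-c3ccc(OC)c(OC)c3)n3nc(-c4ccccc4)cc3n2)cc1`, is not yet measured. It differs from compound 2 in one place: 2-((4-methoxyphenyl)carbonyl)ethenyl in place of (2-(4-chlorophenyl)ethenyl)carbonyl on an aromatic carbon. The change rejoins the 4-methoxyphenyl group seen in compound 1 but with the carbonyl and ethenyl arranged differently along the linker. Among the measured compounds shown here, no measured step bears on this rearrangement; the one step available, the exchange of methoxy for chloro, stayed within the scatter. With nothing pointing either way, a step of a 1.1-fold lower number from compound 2 to compound 3 (0.03 log units; within the scatter) is expected, that is none beyond the scatter, and compound 3 is estimated at 22000 nM with a range from 7000 nM to 70000 nM.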

Compound 3, half-maximal inhibitory concentration: 13900 nM
Estimate against measurement, compound 3: 1.6-fold (0.20 log units) above; the measured number falls inside the stated range.
By their numbers in this assay, from the lowest: compounds 3, 1 and 2 (each within the scatter of the next).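

Reversing the linker on this aromatic carbon, so that the carbonyl sits beside the 4-methoxyphenyl ring instead of beside the core, gives in this assay a 1.6-fold lower number from compound 1 to compound 3 (0.20 log units; within the scatter). Exchanging (2-(4-chlorophenyl)ethenyl)carbonyl for 2-((4-methoxyphenyl)carbonyl)ethenyl, which changes both the linker and the ring substituent, gives a 1.7-fold lower number from compound 2 to compound 3 (0.23 log units; within the scatter). So, while the earlier step concerned only the group on the far ring, these steps show that the linker direction can also be reversed without a difference that stands out from the scatter, and no measurement here offers any further insight into this result.

Going by these compounds, all three compounds keep a carbonyl and an ethenyl in this chain, so it remains open how a simple amine or a carboxylic acid on this carbon would compare. On these data alone, the effect of replacing the 3,4-dimethoxyphenyl group also remains open.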